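Cyclohexyl in place of 3-methoxyphenyl on two cores

This account rests on a few compounds, and the source may have more. Where it says the series, first, only, none or still open, it means among the compounds named here.

Of the compounds shown here, three have been tested in a functional assay on A-375 cells (Homo sapiens) for antiproliferative activity, read by MTT assay, with a stated time of 72 h; on this read-out higher numbers stand for weaker inhibition and lower numbers for stronger inhibition. Compound 1 `COc1cccc(N2C(=O)COc3ccc(-c4cnc(Cl)c(NS(=O)(=O)c5ccc(F)cc5)c4)cc32)c1` carries a 3-methoxyphenyl group on an amide-type nitrogen in a ring; in this assay compound 1 gives only the limit > 40000 nM, not a number. Compound 2 `O=C1COc2ccc(-c3cnc(Cl)c(NS(=O)(=O)c4ccc(F)cc4)c3)cc2N1C1CCCCC1` differs from it by cyclohexyl in place of 3-methoxyphenyl on an amide-type nitrogen in a ring. In this assay compound 2 likewise reaches only the limit > 40000 nM. The step that the two limits leave unreadable from compound 1 to compound 2 is thus unreadable, both values resting at the limit of > 40000 nM in this assay, at which 2 of the 3 values shown sit. Compound 3 `COc1cccc(N2C(=O)COc3ccc(-c4cnc5ccccc5c4)cc32)c1` has a different core; the difference between the two cores is not broken down here. In this assay, for the measured compounds named here, compound 3 gives 23600 nM, the only number among the three. Compound 4 `O=C1COc2ccc(-c3cnc4ccccc4c3)cc2N1C1CCCCC1` is not yet measured and differs from compound 3 by cyclohexyl in place of 3-methoxyphenyl on an amide-type nitrogen in a ring, the same change as from compound 1 to compound 2. That earlier step has no known size, and compound 3 is itself weak. The step expected in this assay is a 1.5-fold higher number from compound 3 to compound 4 (0.17 log units; within the scatter), an estimate resting only on compound 3 at 23600 nM. For compound 4 the expected value is 35000 nM, in a range from 15000 nM to 80000 nM, with a real chance that only a limit is reported.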

Compound 4, half-maximal inhibitory concentration: > 40000 nM
Compound 4 ended at the assay's limit (the forecaster's own chance of this, stated with the estimate: 55%); middle value at least 1.1-fold (0.05 log units) from the limit.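

In this assay compound 4 gives > 40000 nM, which is a limit of the assay and not a number. On the second core, cyclohexyl in place of 3-methoxyphenyl gives an at least 1.6-fold higher number from compound 3 to compound 4 (0.22 log units; that floor lies within the scatter), so the change cannot be said to do more than the usual scatter of repeats, although its true size may be larger. From the compounds shown here alone, the same change on the core of compound 1 cannot be read, so no two sizes can be set side by side, and whether the change carries from one core to the other remains untested, with most values resting at one ceiling: the limit of > 40000 nM in this assay, at which 3 of the 4 values shown sit.

The compounds shown leave open whether another group on the amide-type nitrogen, such as a methyl or a chain ending in an amine, would give clear numbers on both cores. Only such numbers could show whether this position behaves alike on the two cores.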